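This account rests on a few compounds, and the source may have more. Where it says the series, first, only, none or still open, it means among the compounds named here.

Measured so far:
compound 1, `Oc1cccc(-c2cc(-c3ccco3)cc(-c3cccc(O)c3)n2)c1`: 0%
compound 2, `Oc1ccc(-c2cc(-c3ccco3)cc(-c3cccc(O)c3)n2)cc1`: 1.5%
compound 3, `Oc1cccc(-c2cc(-c3ccoc3)cc(-c3ccccc3O)n2)c1`: "not determined" (no result reported)

In an assay on isolated protein for inhibition of DNA topoisomerase 1 (Homo sapiens), with a stated time of 30 min, tested at 20 uM (on this read-out higher numbers stand for a stronger effect at the one concentration tested and lower numbers for a weaker effect), compound 1 gives 0%, and compound 2 gives 1.5%. The change between them, (4-hydroxyphenyl in place of 3-hydroxyphenyl on an aromatic carbon), made a step of a number 1.5 percentage points higher from compound 1 to compound 2 (within the scatter). Compound 4, `Oc1ccc(-c2cc(-c3ccoc3)cc(-c3ccccc3O)n2)cc1`, carries the same kind of change on the core of compound 3: 4-hydroxyphenyl in place of 3-hydroxyphenyl on an aromatic carbon. The surroundings of the place differ: in compound 1 the site is meta to a 3-hydroxyphenyl group and meta to a furan-2-yl group, in compound 3 meta to a 2-hydroxyphenyl group and meta to a furan-3-yl group. The difference between the two cores is not broken down here. Compound 3 has no number in this assay, so the expectation rests only on compound 1 with 0% and compound 2 with 1.5%, both near no inhibition. The step from compound 3 to compound 4 is expected to stay within the scatter, as the earlier one did. Compound 4 is estimated at 3% in this assay, between -5% and 15%.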

Compound 4, a percentage reported as inhibition, at one concentration (the size of the read-out at that concentration, not a potency): 3.9%
Estimate against measurement, compound 4: 0.9 percentage points below, within the range that was stated.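

In this assay, among the compounds shown here, compound 3 has no number, so no step to compound 4 can be read. As far as these compounds go, what the change to 4-hydroxyphenyl does on the core of compound 3 stays open. No evidence bearing on this result is available.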